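The source may hold more compounds than are shown below. What is called first, only, known or untested is meant among the compounds shown, and "the series" means these compounds.

Of the compounds shown here, three share a core and have been measured in an ADME assay on HepG2 cells (Homo sapiens) for inhibition, with a stated time of 48 h; a lower number here means that less compound is needed, a higher number that more compound is needed for the effect. Compound 1 `C[C@@H](C(=O)N1CC2CC2C1)N1CCN(S(=O)(=O)c2ccc(C(C)(C)C)cc2)CC1` gives > 40000 nM, which is a limit of the assay rather than a number. Compound 2 `C[C@H](C(=O)N1CCCCC1)N1CCN(S(=O)(=O)c2ccc(C(C)(C)C)cc2)CC1` gives > 40000 nM, also a limit. Compound 3 `CC(C(=O)N1CCCCC1)N1CCN(S(=O)(=O)c2ccc(C(C)(C)C)cc2)CC1` gives > 40000 nM, again a limit. Compound 3 thus stands where the other two stand, at the limit, and the step that the two limits leave unreadable from compound 2 to compound 3 cannot be read in size because the limit of > 40000 nM in this assay, at which 3 of the 3 values shown sit, and because of the fact that one of compounds 2 and 3 is drawn with a defined configuration and the other without, at the place where they differ. Compound 4 `C[C@@H](C(=O)N1CCCCC1)N1CCN(S(=O)(=O)c2ccc(C(C)(C)C)cc2)CC1` has not been measured; it differs from compound 3 in this way: the two compounds have the same atoms and bonds; at least one stereo element is drawn with a configuration in one of them and without one in the other: 1 of 1 stereo elements differ; a stereocentre at a saturated chain carbon is drawn without a configuration in compound 3 and S in compound 4. For the measured compounds named here, the only measured step touching a change of this kind is a step that the two limits leave unreadable from compound 2 to compound 3, which the limits leave unreadable, so no step in either direction beyond the scatter can be expected in this assay. Compound 4 is expected to give 40000 nM, within 15000 nM to 150000 nM, and most likely only a limit. The step from compound 3 to compound 4 is accordingly expected to be a number no higher from compound 3 to compound 4 (the limit leaves the size open).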

Compound 4, half-maximal effective concentration: > 40000 nM
Compound 4: a limit, no number; the forecaster's own chance of this, stated with the estimate: 85%; the middle value lies on the limit itself.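

The steps from compounds 1, 2 and 3 to compound 4 cannot be read, because each compares two limits rather than two numbers: the limit of > 40000 nM in this assay, at which 4 of the 4 values shown sit. The compounds shown leave open whether the drawn configuration or the group on the carbonyl carbon affects the value in this assay at all.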